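Losing a Benzyl Group on a Ring Amine

This account rests on a few compounds, and the source may have more. Where it says the series, first, only, none or still open, it means among the compounds named here.

Of the compounds shown here, three have been measured so far in an assay on HEK293 cells for inhibition of acid ceramidase (Homo sapiens), read by fluorescence, with stated times of 10 min and 3 h; a lower number here means a stronger inhibitor, a higher number a weaker inhibitor. Compound 2 `O=C(NCCCCc1ccccc1)n1c2c(oc1=O)CCN(Cc1ccccc1)C2` stands second highest of the three numbers: in this assay compound 2 gives 436 nM. Its nearest neighbour is compound 1 `CC(C)N1CCN(c2ccc3c(c2)oc(=O)n3C(=O)NCCCCc2ccccc2)CC1`, which in this assay gives 211 nM, a lower number and a gap beyond the usual scatter. Furthest away is compound 3 `CC(C)CNC(=O)n1c(=O)oc2cc(C3CCCN(C)C3)ccc21`, which in this assay gives 1750 nM, the highest number of the three and again beyond the scatter. None of these three pairs differs in only one place, so no single change has yet been followed on its own.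

Compound 4 `O=C(NCCCCc1ccccc1)n1c2c(oc1=O)CCNC2` has not yet been measured. Compared with compound 2, the change is this: hydrogen in place of benzyl on an amine nitrogen in a ring. Within the data shown here, nothing among the measured compounds shows what stripping a ring amine down to a bare hydrogen does here, so the expectation rests on the change alone. The step from compound 2 to compound 4 is expected to move the number upward, toward a weaker inhibitor, by a 2.8-fold higher number from compound 2 to compound 4 (0.44 log units; beyond the scatter). Compound 4 is therefore expected to give about 1200 nM in this assay, with a likely range from 350 nM to 4500 nM.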

Compound 4, half-maximal inhibitory concentration: 247 nM
Compound 4: the middle estimate sits 4.9-fold (0.69 log units) above what was measured; the measured number lies below the stated range.
By their numbers in this assay, from the lowest: compounds 1, 4 and 2 (each within the scatter of the next, the first and the last beyond it); then compound 3.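

In this assay, taking the benzyl group off the amine nitrogen in the ring and leaving a bare hydrogen gives a 1.8-fold lower number from compound 2 to compound 4 (0.25 log units; within the scatter). Among these compounds, this is the first single change followed on its own in this set, and it shows that a whole benzyl group, with its aromatic ring, can leave this nitrogen without the number moving beyond the usual scatter, so in this pair the inhibition does not depend on that group. Nothing shown gives a reason for this result.

This is one pair with one side chain, so it cannot say whether the same holds on other cores. It also leaves open what a small methyl group, an acetyl group or a longer phenylethyl chain on the same nitrogen would do to the number.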